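The compounds below may be only part of what the source reports. "The series", "measured", "known", "first", "only" and "open" are said of these compounds alone.

Measured so far in an ADME assay on Huh7.5.1 cells (Homo sapiens) for cytotoxicity, read by ATP content, with a stated time of 48 h; on this read-out lower numbers stand for higher toxicity in this test and higher numbers for lower toxicity in this test:
compound 1 `Cc1oc(-c2ccccc2Cl)nc1CN1CCC(C(=O)NCCCN2C[C@H](C)C[C@H](C)C2)CC1` — 16500 nM
compound 2 `Cc1cccc(Cl)c1-c1nc(CN2CCC(C(=O)NCCCN3CCC(C)(C)CC3)CC2)c(C)o1` — 11700 nM

Two compounds of the series have a number in this assay. Compound 1 gives 16500 nM and compound 2 gives 11700 nM; the two values lie within the usual scatter of each other, so neither is set apart from the other. Compound 1 holds the higher of the two numbers, but only by a gap inside the scatter. Among the measured compounds shown here, no measured pair differs in a single place, so no single-change step in this assay is known.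

Compound 3 `COc1cccc(OC)c1-c1nc(CN2CCC(C(=O)NCCCN3C[C@H](C)C[C@H](C)C3)CC2)c(C)o1` has not yet been measured in this assay. It differs from compound 1 in one place: 2,6-dimethoxyphenyl in place of 2-chlorophenyl on an aromatic carbon. For the measured compounds named here, with no measured step of this kind to rest on, the expectation for this change is a step of no more than the scatter, in no settled direction. The value of compound 3 is estimated at 15000 nM, with a range from 6000 nM to 40000 nM. The step from compound 1 to compound 3 that this estimate means is expected to be a 1.1-fold lower number from compound 1 to compound 3 (0.04 log units; within the scatter).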

Compound 3, half-maximal cytotoxic concentration: 77100 nM
Beside the measured number, compound 3's estimate is 5.1-fold (0.71 log units) below it, outside the stated range (above it).
By their numbers in this assay, from the lowest: compounds 2 and 1 (each within the scatter of the next); then compound 3.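

Among the compounds shown here, the exchange of 2-chlorophenyl for 2,6-dimethoxyphenyl, on the aromatic carbon next to the ring nitrogen and next to the ring oxygen, gives the first single-place step in this assay, a 4.7-fold higher number from compound 1 to compound 3 (0.67 log units; beyond the scatter), a modest step that reads as lower toxicity in this test. For the compounds shown here, compounds 1 and 2 differ in more than one place and lie within the scatter of each other, so only this pair shows that the read-out responds to this position, with the rest of compound 1 held unchanged. The change removes the chlorine and brings in two methoxy groups with their hydrogen-bond acceptors, but nothing on hand bears on why the number moves.

From the compounds shown here alone, it remains open whether the step follows from one methoxy group or needs both, a question that 2-methoxyphenyl would address, and whether 2,6-dichlorophenyl or plain phenyl would fall nearer compound 1 or compound 3. Going by these compounds, it is also open whether the same exchange gives a step of similar size on the amine side chain of compound 2.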